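Working notes on a chloro step and cell toxicity

This account rests on a few compounds, and the source may have more. Where it says the series, first, only, none or still open, it means among the compounds named here.

Measured so far in an ADME assay on HepG2 cells (Homo sapiens) for cytotoxicity, read by MTT assay, with a stated time of 72 h; on this read-out lower numbers stand for higher toxicity in this test and higher numbers for lower toxicity in this test:
compound 1 `Oc1ccccc1/C=N/c1sc2c(c1-c1nc3ccccc3s1)CCC2` gives 156 ug/mL
compound 2 `C(=N/c1sc2c(c1-c1nc3ccccc3s1)CCCC2)\c1ccccc1` gives 308 ug/mL
compound 3 `Clc1ccccc1/C=N/c1sc2c(c1-c1nc3ccccc3s1)CCCC2` gives 370 ug/mL

Compound 1 has the lowest of the three numbers in this assay. Its value stands within the scatter of compound 2 but beyond the scatter relative to compound 3. The difference between the cores of compound 1 and compound 2 is not broken down here.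

Compound 3 differs from compound 2 by chloro in place of hydrogen on an aromatic carbon. The measured step is a 1.2-fold higher number from compound 2 to compound 3 (0.08 log units; within the scatter).

Compound 4 `Oc1ccccc1/C=N/c1sc2c(c1-c1nc3cc(Cl)ccc3s1)CCC2` is not yet measured. It differs from compound 1 by chloro in place of hydrogen on an aromatic carbon. Going by the values given here, this is the same kind of change as the one from compound 2 to compound 3, not the same: there the place was ortho to a large group on a ring of carbon only, here the ring is part of a fused or bridged system of two rings, meta to a fused ring and para to a fused ring.

Because a 1.2-fold higher number from compound 2 to compound 3 (0.08 log units; within the scatter) stayed within the scatter, a comparably small step is expected for compound 4, namely a 1.2-fold higher number from compound 1 to compound 4 (0.06 log units; within the scatter). Compound 4 is therefore estimated at 180 ug/mL, with a range from 90 ug/mL to 360 ug/mL.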

Compound 4, half-maximal cytotoxic concentration: 210 ug/mL
Estimate against measurement, compound 4: 1.2-fold (0.07 log units) below, within the range that was stated.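

In this assay, chloro in place of hydrogen on an aromatic carbon gives a 1.3-fold higher number from compound 1 to compound 4 (0.13 log units; within the scatter), and this step agrees with the one seen earlier on the other core: the same change on two cores in this assay, a 1.2-fold higher number (0.08 log units; within the scatter) from compound 2 to compound 3 and a 1.3-fold higher number (0.13 log units; within the scatter) from compound 1 to compound 4, 1.1-fold (0.05 log units) apart, within the scatter of two such steps

For these two pairs, the change therefore carries from one core to the other as a step too small to separate from the scatter of repeated measurements. Going by these compounds alone, this does not show that chloro leaves this read-out unchanged across the series, since only two pairs are available, the chloro sits at a different kind of place in each, and neither step is large enough to give a reliable size or direction.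

Going by these compounds, it remains open whether an amine or a carboxylic acid on the same aromatic carbon of the core of compound 1 would give a step beyond the scatter. On these data alone, a longer chain, such as a butyl group, at that place is equally open.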